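Fluoro Substitution on the Hydrazone Phenyl of Compound 3

A few compounds are considered here, and "the series" means these few. Any claim that something is new, unique, unknown or untested is made for them only; others in the source may bear on it.

Compound 3 `O=C(CSc1nnc(-c2ccncc2)n1-c1ccccc1)N/N=C/c1ccccc1` gives 14700 nM in a functional assay on HCT-116 cells (Homo sapiens) for inhibition, read by MTT assay, with a stated time of 48 h; on this read-out lower numbers stand for stronger inhibition and higher numbers for weaker inhibition. Among the three measured compounds its number stands second highest; compound 1 `Clc1ccc(CSc2nnc(-c3ccncc3)n2-c2ccccc2)cc1` gives 10700 nM and compound 2 `O=[N+]([O-])c1ccc(CSc2nnc(-c3ccncc3)n2-c2ccccc2)cc1` gives 23800 nM, both within the scatter of compound 3. Compound 4 `O=C(CSc1nnc(-c2ccncc2)n1-c1ccccc1)N/N=C/c1ccccc1F` differs from compound 3 by fluoro in place of hydrogen on an aromatic carbon. Among the measured compounds shown here, the only measured step, a 2.2-fold higher number from compound 1 to compound 2 (0.35 log units; beyond the scatter), concerns a different substituent on a different ring and does not bear on this change. For the measured compounds named here, no measured step tests fluoro against hydrogen, so no shift beyond the scatter is expected in this assay. Compound 4 is therefore expected near 13000 nM, between 6000 nM and 30000 nM. The expected step of a 1.1-fold lower number from compound 3 to compound 4 (0.05 log units; within the scatter) stays within the scatter.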

Compound 4, half-maximal inhibitory concentration: 18000 nM
For compound 4 the middle estimate is 1.4-fold (0.14 log units) below the measured one; the range from low to high includes it.
By their numbers in this assay, from the lowest: compounds 1, 3, 4 and 2 (each within the scatter of the next, the first and the last beyond it).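

Phenyl to 2-fluorophenyl on the hydrazone gives a 1.2-fold higher number from compound 3 to compound 4 (0.09 log units; within the scatter) in this assay so a single fluoro ortho to a large group leaves the number within the scatter. Among the compounds shown here, this is the first reading of a substituent on this ring, which the earlier compounds did not vary. Nothing at hand gives a cause for this result.

As far as these compounds go, whether a trifluoromethyl, a methoxy or an amine at this place would move the number beyond the scatter stays open. So does the effect of fluoro elsewhere on this ring.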